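Crown Ether Esters That Leave Growth Inhibition Unresolved

The source may hold more compounds than are shown below. What is called first, only, known or untested is meant among the compounds shown, and "the series" means these compounds.

Three esters of the same crown ether methanol have been examined in a functional assay on WiDr cells (Homo sapiens) for inhibition, read by sulforhodamine B assay, with a stated time of 48 h; a higher number here means a weaker inhibitor of growth, a lower number a stronger inhibitor of growth. Compound 1 (`O=C(/C=C/c1ccccc1)OCC1COCCOCCOCCOCCOCCO1`) gives only a limit of the assay, > 100000 nM. Compound 2 (`O=C(CCCCOc1ccccc1)OCC1COCCOCCOCCOCCOCCO1`) likewise gives a limit, > 100000 nM. Compound 3 (`O=C(OCC1COCCOCCOCCOCCOCCO1)c1cccnc1`) also gives a limit, > 100000 nM. Because all three sit at the limit of > 100000 nM in this assay, at which 3 of the 3 values shown sit, the steps among them cannot be read: a step that the two limits leave unreadable from compound 1 to compound 2, a step that the two limits leave unreadable from compound 1 to compound 3 and a step that the two limits leave unreadable from compound 2 to compound 3. Compound 3 therefore stands nowhere on a scale of numbers and merely shares the common limit.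

Compound 4 (`CC(=O)OCC1COCCOCCOCCOCCOCCO1`) differs from compound 3 by methyl in place of pyridin-3-yl on a carbonyl carbon. None of the three measured steps has a readable size, so no direction or magnitude of the step in this assay can be drawn from them; what can be said is that every change on the carbonyl carbon so far has left the value at the limit. Compound 4 is accordingly expected to remain at the limit as well, with an estimated value of 150000 nM (range 50000 nM to 500000 nM). The resulting step is thus estimated as a step that the limit leaves unreadable from compound 3 to compound 4.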

Compound 4, concentration for 50% growth inhibition: > 100000 nM
Compound 4 gave a limit, no number (the forecaster's own chance of this, stated with the estimate: 90%); the middle value lies beyond the limit too.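

Compound 4 also gives only a limit, so no new step from compound 1, compound 2 or compound 3 to it can be read: the limit of > 100000 nM in this assay, at which 4 of the 4 values shown sit.

The compounds shown leave open whether any change on the carbonyl carbon of the shared core would give a readable number in this assay.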